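One More Chlorine on the Chlorophenyl End

This account rests on a few compounds, and the source may have more. Where it says the series, first, only, none or still open, it means among the compounds named here.

In a functional assay on cells (T-cell line, Homo sapiens) for inhibition (on this read-out higher numbers stand for weaker inhibition and lower numbers for stronger inhibition), compound 1 (`CN1CCC(COC(c2ccccc2)c2ccccc2)CC1`) gives > 20000 nM as its reading, which is a limit of the assay. Compound 2 (`Clc1ccc(CCCN2CCC(COC(c3ccccc3)c3ccccc3)CC2)cc1`) gives 500 nM and compound 3 (`Clc1ccccc1CCCN1CCC(COC(c2ccccc2)c2ccccc2)CC1`) gives 800 nM in the same test. Two large steps (an at least 40-fold lower number from compound 1 to compound 2 (1.60 log units; beyond the scatter)) and (an at least 25-fold lower number from compound 1 to compound 3 (1.39 log units; beyond the scatter)) came with placing 2-(4-chlorophenyl)ethyl or 2-(2-chlorophenyl)ethyl in place of hydrogen. Exchanging 4-chlorophenyl for 2-chlorophenyl gave only a small step (a 1.6-fold higher number from compound 2 to compound 3 (0.20 log units; within the scatter)), so compound 3 stands level with compound 2 within the scatter.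

Compound 4 (`Clc1ccc(CCCN2CCC(COC(c3ccccc3)c3ccccc3)CC2)cc1Cl`) differs from compound 3 as follows (3,4-dichlorophenyl in place of 2-chlorophenyl on a saturated chain carbon, three bonds along the chain from an amine nitrogen in a ring): 3,4-dichlorophenyl stands in place of 2-chlorophenyl, on a saturated chain carbon, three bonds along the chain from an amine nitrogen in a ring. Compound 4 keeps the chain behind the large steps, so the closest guide is the small step between compound 2 and compound 3 (a 1.6-fold higher number from compound 2 to compound 3 (0.20 log units; within the scatter)). No step beyond the scatter is therefore expected (a 1.8-fold lower number from compound 3 to compound 4 (0.25 log units; within the scatter)). Compound 4 is estimated at 450 nM with a likely range of 150 nM to 1200 nM in this read-out.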

Compound 4, half-maximal inhibitory concentration: 2200 nM
Compound 4: middle estimate off by 4.9-fold (0.69 log units), on the low side; the measured number lies above the stated range.
By their numbers in this assay, from the lowest: compounds 2 and 3 (each within the scatter of the next); then compound 4. At a limit, above all of these: compound 1.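

Adding a second chlorine to compound 2 weakens inhibition in this assay, with a 4.4-fold higher number from compound 2 to compound 4 (0.64 log units; beyond the scatter), and exchanging 2-chlorophenyl for 3,4-dichlorophenyl gives a 2.8-fold higher number from compound 3 to compound 4 (0.44 log units; beyond the scatter). The chlorine pattern on this ring therefore matters, which the earlier pair of compound 2 and compound 3 did not reveal. The added chain still goes with stronger inhibition, with an at least 9.0-fold lower number from compound 1 to compound 4 (0.95 log units; beyond the scatter), but compound 1 reads at a limit, so this step is only a bound: the limit of > 20000 nM in this assay, at which 1 of the 4 values shown sits.

On these data alone, whether the weaker reading follows from the number of chlorines or from where they sit remains open. Also open, as far as these compounds go, is how this read-out would respond to a longer chain, or to an amine or a carboxylic acid in place of the chlorines.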